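Swapping the Ethynyl for a Chlorobutyl Chain on the Amide

A few compounds are considered here, and "the series" means these few. Any claim that something is new, unique, unknown or untested is made for them only; others in the source may bear on it.

Compound 1 `C#CC(=O)N(Cc1ccc(OC)c(O)c1)c1cc(OC)c(OC)c(OC)c1` gives the lowest of the two numbers recorded so far: in a functional assay on KYSE-450 cells (Homo sapiens) for inhibition, read by MTT assay, with a stated time of 48 h (on this read-out lower numbers stand for stronger inhibition and higher numbers for weaker inhibition), compound 1 gives 570 nM. In this assay compound 2 `COc1cc(NCc2cccc(O)c2)cc(OC)c1OC` gives 71300 nM, a gap that lies well beyond the usual scatter. Compound 3 `COc1ccc(CN(C(=O)CCCCCl)c2cc(OC)c(OC)c(OC)c2)cc1O` keeps the core of compound 1 and differs in one place: 4-chlorobutyl in place of ethynyl on a carbonyl carbon. Going by the values given here, no measured pair shows this exact change, so its effect must be judged without precedent. Compound 3 is expected to be weaker, with the step of an 11-fold higher number from compound 1 to compound 3 (1.02 log units; beyond the scatter) estimated to reach beyond the scatter. The value for compound 3 is estimated at 6000 nM, within a range from 1200 nM to 30000 nM.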

Compound 3, half-maximal inhibitory concentration: 770 nM
Compound 3: the middle estimate sits 7.8-fold (0.89 log units) above what was measured; measured number below the stated range.
By their numbers in this assay, from the lowest: compounds 1 and 3 (each within the scatter of the next); then compound 2.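

Exchanging the ethynyl for 4-chlorobutyl leaves this assay within the usual scatter, with a 1.4-fold higher number from compound 1 to compound 3 (0.13 log units; within the scatter). In this one pair, then, the triple bond is not needed to keep the read-out in the range of compound 1, and a chain ending in chlorine serves as well. No measurement available here accounts for this match. Still open, as far as these compounds go, is how far this tolerance extends: whether a longer chain would read the same, and whether an amine or a carboxylic acid could take the place of the chlorine.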